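Aryl ring in place of the alkyne of compound 1

The source may report more compounds than this note shows. Statements on the series, on what has been measured and on what is new or still open speak of the compounds shown alone.

Compound 1 `CC(C)(O)C#Cc1cc(C(O)(C(F)(F)F)C(F)(F)F)cnc1N1CCN(S(=O)(=O)c2ccc(N)nc2)CC1` was tested in an ADME assay (liver) for metabolic stability, with Liver microsome (Homo sapiens) as the target, using microsomes and NADPH, with a stated time of 30 min, tested at 1 uM (a higher number here means faster removal of the compound, a lower number slower removal), and in this assay compound 1 gives only a limit, < 14 mL.min-1.g-1. Compound 2 `Nc1ccc(S(=O)(=O)N2CCN(c3ncc(C(O)(C(F)(F)F)C(F)(F)F)cc3C#CCCO)CC2)cn1` also gives only a limit, < 14 mL.min-1.g-1. Compound 3 `Nc1ccc(S(=O)(=O)N2CCN(c3ncc(C(O)(C(F)(F)F)C(F)(F)F)cc3-c3cccc(F)c3)CC2)cn1` gives a number, 25 mL.min-1.g-1. The step of an at least 1.7-fold higher number from compound 1 to compound 3 (0.25 log units; that floor lies within the scatter) and the step of an at least 1.7-fold higher number from compound 2 to compound 3 (0.25 log units; that floor lies within the scatter) each exchange a chain carrying a triple bond for an aromatic ring, whereas the step that the two limits leave unreadable from compound 1 to compound 2 cannot be read, since the limit of < 14 mL.min-1.g-1 in this assay, at which 2 of the 3 values shown sit, covers both of its values. Compound 4 `Nc1ccc(S(=O)(=O)N2CCN(c3ncc(C(O)(C(F)(F)F)C(F)(F)F)cc3-c3ccccc3O)CC2)cn1` differs from compound 1 in one place: 2-hydroxyphenyl in place of 3-hydroxy-3-methylbut-1-yn-1-yl on an aromatic carbon. This change too exchanges a chain with a triple bond for an aromatic ring, and the step of an at least 1.7-fold higher number from compound 1 to compound 3 (0.25 log units; that floor lies within the scatter) is therefore the closest guide. A rise of about that size is expected, an at least 1.7-fold higher number from compound 1 to compound 4 (0.25 log units; that floor lies within the scatter). Compound 4 is thus estimated at 25 mL.min-1.g-1, likely between 10 mL.min-1.g-1 and 60 mL.min-1.g-1.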

Compound 4, intrinsic clearance in microsomes: 22 mL.min-1.g-1
Estimate against measurement, compound 4: 1.1-fold (0.06 log units) above; low and high end bracket the measured number.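

In this assay, exchanging 3-fluorophenyl for 2-hydroxyphenyl at this position gives a 1.1-fold lower number from compound 3 to compound 4 (0.06 log units; within the scatter), so two differently substituted aryl rings now read alike. Set against the two alkyne chains, the 2-hydroxyphenyl ring gives an at least 1.5-fold higher number from compound 1 to compound 4 (0.19 log units; that floor lies within the scatter) and an at least 1.5-fold higher number from compound 2 to compound 4 (0.19 log units; that floor lies within the scatter). Each of these floors rests on a limit and not on a number: the limit of < 14 mL.min-1.g-1 in this assay, at which 2 of the 4 values shown sit.

As far as these compounds go, how far compound 1 and compound 2 truly lie from the aryl compounds stays open. Also open, from the compounds shown here alone, is whether a phenyl ring carrying an amine or a carboxylic acid would read the same here.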